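From chloro to bromo in compound 3

This account rests on a few compounds, and the source may have more. Where it says the series, first, only, none or still open, it means among the compounds named here.

Compound 1 `O=C(CCCOc1cccc(C(F)(F)F)c1)Nc1ncc(Cl)s1` gives 2500 nM
Compound 2 `Cc1cc(OCCCC(=O)Nc2ncc(Cl)s2)ccc1Cl` gives 4400 nM

In an ADME assay on HepG2 cells (Homo sapiens) for cytotoxicity, read by CellTiter-Glo, with a stated time of 48 h (a higher number here means that more compound is tolerated, a lower number that less compound is tolerated), compound 2 gives 4400 nM and compound 1 gives 2500 nM so these two sit within the usual scatter of repeated measurements and cannot be told apart. They also differ in more than one place, so they offer no clean single change to learn from.

Compound 3 `Cc1cc(OCCCC(=O)Nc2ncc(Br)s2)ccc1Cl` is compound 2 with one exchange (bromo in place of chloro on an aromatic carbon), bromo in place of chloro on an aromatic carbon, next to the ring sulfur. Among the compounds with values here, no measured pair shows this exchange, so the expectation starts from compound 2 at 4400 nM and assumes little movement. The estimated step (a 1.1-fold lower number from compound 2 to compound 3 (0.04 log units; within the scatter)) is expected to stay within the scatter, with no firm direction. In this assay the expected value for compound 3 is 4000 nM (estimated range 1800 nM to 9000 nM).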

Compound 3, half-maximal cytotoxic concentration: 4000 nM
For compound 3 middle estimate and measured number coincide at the digits printed; low and high end bracket the measured number.
By their numbers in this assay, from the lowest: compounds 1, 3 and 2 (each within the scatter of the next).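

Within the data shown here, the step of a 1.1-fold lower number from compound 2 to compound 3 (0.04 log units; within the scatter) in this assay is the first comparison here that differs in one place only, since compound 1 and compound 2 differ in more than one. It shows that 5-chloro-1,3-thiazol-2-yl and 5-bromo-1,3-thiazol-2-yl cannot be told apart in this read-out when the rest of compound 2 is kept, so at this position, next to the ring sulfur, one halogen can stand in for the other without a measurable difference. Nothing measured here explains this result.

Chloro and bromo are the only groups shown at this position, so it remains open whether a smaller hydrogen, a methyl group, a nitrile or an amine there would give a number beyond the scatter. As far as these compounds go, it is also open whether the same exchange would read alike on the trifluoromethyl-bearing compound 1.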